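Decyl for silyl on the triazole-bearing furanone series

The source may report more compounds than this note shows. Statements on the series, on what has been measured and on what is new or still open speak of the compounds shown alone.

Compound 1 `C[Si](C)(C)c1cn(C[C@H](O)[C@H]2OC(=O)C(OCc3ccccc3)=C2OCc2ccccc2)nn1` carries a small silicon-containing group on the five-membered aromatic ring with 3 nitrogen. In a functional assay on SW-620 cells (Homo sapiens) for antiproliferative activity, read by MTT assay, with a stated time of 72 h (on this read-out lower numbers stand for stronger inhibition and higher numbers for weaker inhibition), compound 1 gives 56000 nM, which is the higher of the two numerical values in hand, with compound 3 `O=C1O[C@H]([C@@H](O)Cn2cc(-c3cc(C(F)(F)F)cc(C(F)(F)F)c3)nn2)C(OCc2ccccc2)=C1OCc1ccccc1` giving 49200 nM; the two lie within the scatter of each other, so no order between them can be read. Compound 2 `O=C1O/C(=C\Cn2cc(-c3ccc(Br)cc3)nn2)C(OCc2ccccc2)=C1OCc1ccccc1` gives only a limit in this assay, > 100000 nM, as summed up in the limit of > 100000 nM in this assay, at which 1 of the 3 values shown sits. Among the compounds with values here, no pair of measured compounds differs in a single place, so no measured step is available.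

Compound 4 `CCCCCCCCCCc1cn(C[C@H](O)[C@H]2OC(=O)C(OCc3ccccc3)=C2OCc2ccccc2)nn1` is not yet measured. It differs from compound 1 by a group of 10 heavy atoms (10 carbon; no ring) in place of a group of 4 heavy atoms (3 carbon, 1 silicon; no ring), on an aromatic carbon. Within the data shown here, nothing in the numbers so far speaks to a chain of this kind. The expectation for compound 4 is therefore a number close to that of compound 1, with the step from compound 1 to compound 4 estimated at a 1.9-fold lower number from compound 1 to compound 4 (0.27 log units; within the scatter), a move that may or may not exceed the scatter. Compound 4 is expected to give about 30000 nM in this assay, with a likely range from 8000 nM to 100000 nM.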

Compound 4, half-maximal inhibitory concentration: 45200 nM
Compound 4: middle estimate off by 1.5-fold (0.18 log units), on the low side, within the range that was stated.
By their numbers in this assay, from the lowest: compounds 4, 3 and 1 (each within the scatter of the next). At a limit, above all of these: compound 2.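

Within the data shown here, this is the only measured step that changes one place: on an aromatic carbon of the five-membered aromatic ring with 3 nitrogen, decyl replaces the silicon-containing group, and this assay shows a 1.2-fold lower number from compound 1 to compound 4 (0.09 log units; within the scatter). For this pair, then, going from a group of 4 heavy atoms to an unbranched chain of 10 heavy atoms, neither with a ring, does not move the number beyond the scatter, so the two groups cannot be told apart on this read-out. Nothing in the data in hand accounts for this flat step.

Still open, going by these compounds, is whether any group at this carbon can move the number beyond the scatter: a butyl chain, a chain longer than decyl, a chain ending in an amine or a carboxylic acid would each test this. Also open is what the two benzyl ethers on the shared core contribute, since no pair shown varies them and a free hydroxyl in their place would address that.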